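The source may report more compounds than this note shows. Statements on the series, on what has been measured and on what is new or still open speak of the compounds shown alone.

Compound 1 `O=C(O)C1=Cc2ccccc2OC1(OCc1cc(-c2ccc([N+](=O)[O-])cc2)no1)C(F)(F)F` and compound 2 `O=C(O)C1=Cc2ccccc2OC1(OCc1cc(-c2ccc3ccccc3c2)no1)C(F)(F)F` share one core and differ only in the group on an aromatic carbon. In a functional assay on HeLa cells (Homo sapiens) for inhibition, read by MTT assay, with a stated time of 24 h (on this read-out higher numbers stand for weaker inhibition and lower numbers for stronger inhibition), compound 1 reaches only the limit of the assay, > 150000 nM. In this assay compound 2 also reaches only the limit of the assay, > 150000 nM. The step that the two limits leave unreadable from compound 1 to compound 2 is therefore unreadable, because of the limit of > 150000 nM in this assay, at which 2 of the 2 values shown sit. Compound 3 `O=C(O)C1=Cc2ccccc2OC1(OCc1cc(-c2ccc(F)cc2F)no1)C(F)(F)F` carries 2,4-difluorophenyl in place of naphthalen-2-yl on an aromatic carbon. No readable step bears on this change, so compound 3 is expected to remain near the limit, an expected step that the limit leaves unreadable from compound 2 to compound 3. The estimate for compound 3 is 200000 nM, ranging from 100000 nM to 600000 nM.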

Compound 3, half-maximal inhibitory concentration: > 150000 nM
Compound 3: no number, only a limit; the forecaster's own chance of this, stated with the estimate: 80%; the middle value lies beyond the limit too.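

No step can be read from compound 1 or compound 2 to compound 3, because all three compounds give only a limit and no number: the limit of > 150000 nM in this assay, at which 3 of the 3 values shown sit. The compounds shown leave open how far these three differ, and whether any group at this place on the shared core gives a measurable value.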